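Swapping the aryl amine on a shared urea core

The compounds below may be only part of what the source reports. "The series", "measured", "known", "first", "only" and "open" are said of these compounds alone.

Measured so far:
- compound 1, `COc1cc(Br)ccc1Nc1cc(NC(=O)Nc2c(Cl)cccc2Cl)ncn1`: 47.3%
- compound 2, `COc1cc(NC(=O)Nc2cc(Nc3cc(C)cc(F)c3)ncn2)cc(OC)c1`: 28.3%
- compound 3, `COc1cc(NC(=O)Nc2cc(Nc3ccc(F)c(Cl)c3)ncn2)cc(OC)c1`: 53%

In a functional assay on NCI-H1581 cells (Homo sapiens) for inhibition, read by MTT assay, with a stated time of 48 h, tested at 10 uM (a lower number here means less inhibition, a higher number more inhibition at the concentration tested (going by the name of the read-out)), compound 3 holds the highest of the three numbers, yet compound 1 sits within the scatter of it, so no order between those two can be claimed. Compound 4, `COc1cc(NC(=O)Nc2cc(Nc3ccc(Br)cc3OC)ncn2)cc(OC)c1`, differs from compound 3 by 4-bromo-2-methoxyphenyl in place of 3-chloro-4-fluorophenyl on a nitrogen on an aromatic ring. Among the compounds with values here, the one step on this nitrogen, a number 24.7 percentage points higher from compound 2 to compound 3 (beyond the scatter), shows that changing the aryl group there can move the read-out by a modest amount. Compound 1 already carries 4-bromo-2-methoxyphenyl on that nitrogen and gives 47.3%, close to compound 3. A step of a number 7 percentage points lower from compound 3 to compound 4 (within the scatter) is therefore expected, lying within the scatter. Compound 4 is estimated at 46%, with a range from 28% to 64%.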

Compound 4, a percentage reported as inhibition, at one concentration (the size of the read-out at that concentration, not a potency): 20.1%
For compound 4 the middle estimate is 25.9 percentage points above the measured one; the whole stated range lies above it.
By their numbers in this assay, from the lowest: compounds 4 and 2 (each within the scatter of the next); then compounds 1 and 3 (each within the scatter of the next).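

Swapping 3-chloro-4-fluorophenyl for 4-bromo-2-methoxyphenyl on this nitrogen gives, in this assay, a step of a number 32.9 percentage points lower from compound 3 to compound 4 (beyond the scatter), the largest change seen at this position. The same group does not give the same result in every compound: with it held in place, the change on the amide-type nitrogen gives a number 27.2 percentage points lower from compound 1 to compound 4 (beyond the scatter), so the two ends of the urea cannot be judged separately. Against 3-fluoro-5-methylphenyl, it gives only a number 8.2 percentage points lower from compound 2 to compound 4 (within the scatter).

Nothing measured here explains these steps. Going by these compounds, how an aryl group carrying an amine or a carboxylic acid would behave on this nitrogen remains open.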